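The compounds below may be only part of what the source reports. "The series", "measured", "known", "first", "only" and "open" are said of these compounds alone.

Three compounds built on a shared core were tested in an ADME assay on BEAS-2B cells (Homo sapiens) for cytotoxicity, read by MTT assay, with a stated time of 72 h; on this read-out lower numbers stand for stronger inhibition of growth and higher numbers for weaker inhibition of growth. Among the measured compounds shown here, compound 2 `Nc1nc([SeH])nc2ncccc12` gives 87700 nM in this assay, and this is the only plain number in the set. Compound 1 `CCCCC[Se]c1nc([Se]CCCCC)c2cccnc2n1` reaches a limit of this assay, > 100000 nM. That result is the limit of > 100000 nM in this assay, at which 1 of the 3 values shown sits. For compound 3 `[SeH]c1nc([SeH])c2cccnc2n1` this assay records "not determined" (no result reported), so no result was reported for it. Compound 4 `CCCCC[Se]c1nc(N)c2cccnc2n1` has not yet been measured; it differs from compound 2 by pentyl in place of hydrogen on a selenium. For the measured compounds named here, no step between two measured compounds is available here, so the size of this change cannot be read from a measured pair. Compound 1, which carries pentyl on selenium, stands at the limit, and compound 2, which carries hydrogen on selenium, gives a weak number, so the pentyl change is expected to move the number upward only modestly, near the edge of the usual scatter. Compound 4 is therefore expected to give about 110000 nM in this assay, within a range from 45000 nM to 270000 nM. This estimate means an expected step of a 1.3-fold higher number from compound 2 to compound 4 (0.10 log units; within the scatter), with a fair chance that this assay reports only a limit for compound 4.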

Compound 4, concentration for total growth inhibition: 44900 nM
Compound 4: middle estimate off by 2.4-fold (0.39 log units), on the high side; the whole stated range lies above it.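

In this assay, pentyl in place of hydrogen on a selenium gives a 2.0-fold lower number from compound 2 to compound 4 (0.29 log units; within the scatter), so this change on its own cannot be told apart from repeat-measurement noise. Among the compounds shown here, the other change, one nitrogen atom in place of a group of 6 heavy atoms on an aromatic carbon, gives an at least 2.2-fold lower number from compound 1 to compound 4 (0.34 log units; beyond the scatter), the only step here that clears the scatter. That step can be stated only as a minimum because compound 1 sits at a limit of the assay, not at a true number: the limit of > 100000 nM in this assay, at which 1 of the 4 values shown sits.

Going by these compounds, on the selenium, only hydrogen and pentyl appear, so it remains open how a methyl, a benzyl or a longer chain such as octyl would read. On these data alone, on the aromatic carbon, it also remains open whether a hydroxyl or a methylamino group would behave like the nitrogen of compound 4.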